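Removing the para-methyl: from compound 2 to compound 3

The source may report more compounds than this note shows. Statements on the series, on what has been measured and on what is new or still open speak of the compounds shown alone.

The series shares one core, carried by compound 1 `COc1ccc(C2=NN(C(=O)CN3CCCCC3)C(c3ccccc3O)C2)cc1` and compound 2 `Cc1ccc(C2=NN(C(=O)CN3CCCCC3)C(c3ccccc3O)C2)cc1`, and is read in an assay on isolated protein for inhibition of Amine oxidase [flavin-containing] A (Homo sapiens), read by fluorescence, with stated times of 15 min and 20 min; a lower number here means a stronger inhibitor, a higher number a weaker inhibitor. In this assay compound 1 gives 12700 nM, and compound 2 gives 11300 nM. For the measured compounds named here, the one step measured so far, a 1.1-fold lower number from compound 1 to compound 2 (0.05 log units; within the scatter), is a small one. Compound 2 therefore holds the lowest of the two numbers, but its gap to compound 1 lies within the scatter, so the two cannot be ordered.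

Compound 3 `O=C(CN1CCCCC1)N1N=C(c2ccccc2)CC1c1ccccc1O` is the next step. It differs from compound 2 in a single place: hydrogen in place of methyl on an aromatic carbon. Going by the values given here, the one step that bears on this, a 1.1-fold lower number from compound 1 to compound 2 (0.05 log units; within the scatter), exchanged one small substituent for another at the same aromatic carbon and moved the number very little. With no other guide, the same sort of change is expected here: removal of the methyl is estimated to leave the number for compound 3 near that of compound 2, at a 1.2-fold higher number from compound 2 to compound 3 (0.09 log units; within the scatter), with no shift beyond the scatter.

Compound 3 is thus estimated at 14000 nM in this assay, within a range of 6000 nM to 32000 nM.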

Compound 3, half-maximal inhibitory concentration: 9510 nM
The estimate for compound 3 lay 1.5-fold (0.17 log units) above the measured number; the range from low to high includes it.
By their numbers in this assay, from the lowest: compounds 3, 2 and 1 (each within the scatter of the next).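

In this assay, removing the substituent altogether from this aromatic carbon, para to a large group, gives a step that stays inside the scatter (a 1.2-fold lower number from compound 2 to compound 3 (0.07 log units; within the scatter)), so the change from 4-methylphenyl to phenyl cannot be distinguished from no change at all. The comparison with the methoxy compound reads the same way (a 1.3-fold lower number from compound 1 to compound 3 (0.13 log units; within the scatter)): with hydrogen, methyl and methoxy now compared on this carbon, compounds 1, 2 and 3 cannot be ordered, and the number does not depend on any substituent among these three, which the earlier pair alone could not show. Nothing available explains why this carbon tolerates these exchanges so evenly.

The compounds shown leave open whether a group of a different kind on this carbon, such as a carboxylic acid, an amine or a longer chain, would shift the number beyond the scatter. They also leave open what a change elsewhere on the shared core would do, since all three compounds differ only at this one place.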